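A few compounds are considered here, and "the series" means these few. Any claim that something is new, unique, unknown or untested is made for them only; others in the source may bear on it.

In a functional assay on HeLa cells (Homo sapiens) for cytotoxicity, read by MTT assay, with a stated time of 72 h (on this read-out higher numbers stand for weaker inhibition and lower numbers for stronger inhibition), three compounds with a shared core have been measured, and they differ only in the aryl group on an aromatic nitrogen. Compound 1 `Cn1ccc2c(Oc3ccc(NC(=O)c4cc5cccnc5n(-c5ccc(Br)cc5)c4=O)cc3)ncnc21` with 4-bromophenyl gives 43800 nM as its half-maximal inhibitory concentration. Compound 2 `Cn1ccc2c(Oc3ccc(NC(=O)c4cc5cccnc5n(-c5ccc(C(F)(F)F)cc5Cl)c4=O)cc3)ncnc21` with 2-chloro-4-(trifluoromethyl)phenyl gives 174000 nM on the same read-out. Compound 3 `Cn1ccc2c(Oc3ccc(NC(=O)c4cc5cccnc5n(-c5ccc(C(F)(F)F)c(Cl)c5)c4=O)cc3)ncnc21` with 3-chloro-4-(trifluoromethyl)phenyl gives 289000 nM on that read-out too. Compound 3 stands level with compound 2, as the gap of a 1.7-fold higher number from compound 2 to compound 3 (0.22 log units; within the scatter) shows. Against compound 1 it lies clearly on the weaker side, with a 6.6-fold higher number from compound 1 to compound 3 (0.82 log units; beyond the scatter) as the measured gap, and the other chlorinated analogue shows a 4.0-fold higher number from compound 1 to compound 2 (0.60 log units; beyond the scatter) in the same direction.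

Compound 4 `Cn1ccc2c(Oc3ccc(NC(=O)c4cc5cccnc5n(-c5ccc(C(F)(F)F)c(Cl)c5)c4=O)cc3F)ncnc21` differs from compound 3 by fluoro in place of hydrogen on an aromatic carbon with fluoro in place of hydrogen on an aromatic carbon of a six-membered aromatic ring of carbon only, ortho to a large group and meta to a large group. All measured steps concern the group on the aromatic nitrogen, so none of them tests this change directly. Among the measured compounds shown here, the only guide is the modest size of those steps, and the estimate therefore starts from compound 3 at 289000 nM as its anchor. The estimated change is a 1.3-fold lower number from compound 3 to compound 4 (0.10 log units; within the scatter) and no shift beyond the scatter is expected in either direction. For compound 4 the estimate is 230000 nM with an expected range from 80000 nM to 600000 nM in all.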

Compound 4, half-maximal inhibitory concentration: 156000 nM
For compound 4 the middle estimate is 1.5-fold (0.17 log units) above the measured one; the measured number falls inside the stated range.
By their numbers in this assay, from the lowest: compound 1; then compounds 4, 2 and 3 (each within the scatter of the next).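

In this assay, fluoro in place of hydrogen on an aromatic carbon, ortho to a large group and meta to a large group, is the only change shown outside the group on the aromatic nitrogen, and it gives a 1.9-fold lower number from compound 3 to compound 4 (0.27 log units; within the scatter). With 3-chloro-4-(trifluoromethyl)phenyl held fixed, this position therefore takes a fluoro without a shift beyond the scatter, whereas the change on the aromatic nitrogen gives a 6.6-fold higher number from compound 1 to compound 3 (0.82 log units; beyond the scatter), which lies beyond it. No measurement is available that would explain why the fluoro leaves the number within the scatter.

Going by these compounds, it remains open whether a different group on this same carbon, such as a chloro, a methoxy group, a nitrile or an amine, would also stay level with compound 3, and whether fluoro here would do the same with the 4-bromophenyl group of compound 1 on the aromatic nitrogen. The compounds shown also leave open what the fluoro does on any read-out other than this cell assay, since all four values come from that one.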